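A few compounds are considered here, and "the series" means these few. Any claim that something is new, unique, unknown or untested is made for them only; others in the source may bear on it.

The study concerns inhibitors of acid ceramidase, compared in an assay on HEK293 cells for inhibition of acid ceramidase (Homo sapiens), with a stated time of 10 min; a lower number here means a stronger inhibitor, a higher number a weaker inhibitor. Compound 1 `O=C(NCCCc1ccccc1)n1c(=O)oc2ccccc21` gives 55 nM in this assay. Compound 3 `O=C(NCCCCc1ccccc1)n1c(=O)oc2ccc(F)cc21` gives 12 nM in this assay, and for compound 2 `O=C(NCCCCc1ccccc1)n1c(=O)oc2cccc(Br)c21` the entry in this assay reads no result reported. Among the two numbers, compound 1 therefore stands at the higher one, with compound 3 showing a lower number by a margin that lies beyond the usual scatter of repeated measurements. Compound 1 and compound 3 differ from each other in more than one place, so their two values alone cannot be tied to any single change.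

Compound 4 `O=C(NCCCCc1cccs1)n1c(=O)oc2ccccc21` has not yet been measured. It differs from compound 1 by (thiophen-2-yl)methyl in place of phenyl on a saturated chain carbon, three bonds along the chain from an amide-type nitrogen. Among the measured compounds shown here, no pair of measured compounds differs in just one place, so there is no calibrated step on which to rest this change, and the expectation is correspondingly uncertain. The step from compound 1 to compound 4 is expected to be small, of about the size of the scatter, leaning if anything toward a lower number, and the estimated step is a 1.4-fold lower number from compound 1 to compound 4 (0.14 log units; within the scatter). For compound 4 the estimated value in this assay is 40 nM, with a range from 12 nM to 130 nM.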

Compound 4, half-maximal inhibitory concentration: 37 nM
Compound 4: the middle estimate sits 1.1-fold (0.03 log units) above what was measured, within the range that was stated.
By their numbers in this assay, from the lowest: compound 3; then compounds 4 and 1 (each within the scatter of the next).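

In this assay, among the compounds shown here, the change of phenyl to (thiophen-2-yl)methyl gives the first step in this set that can be read at a single place: a 1.5-fold lower number from compound 1 to compound 4 (0.17 log units; within the scatter), which lies within the scatter, so the two compounds cannot be told apart in this assay. At this place, on a saturated chain carbon, three bonds along the chain from an amide-type nitrogen, a six-membered aromatic ring of carbon only can thus give way to a five-membered aromatic ring containing sulfur with no measurable change in the read-out. The same difference also reads as benzyl to 2-(thiophen-2-yl)ethyl, so the ring and the chain change together in this one step, and nothing measured on these compounds explains the result.

The compounds shown leave open how a thiophen-2-yl ring and the chain length would each act alone, and whether a longer chain carrying the same ring would fit this pattern. Also open, as far as these compounds go, is what a furan-2-yl ring, a pyridine ring, an amine or a carboxylic acid would do at this place.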